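The compounds below may be only part of what the source reports. "The series", "measured", "known", "first", "only" and "open" are said of these compounds alone.

In a functional assay on A549 cells (Homo sapiens) for antiproliferative activity, read by MTT assay, with a stated time of 48 h (a higher number here means a weaker inhibitor, a lower number a stronger inhibitor), compound 1 `COc1ccc(/C=C/C(=O)Nc2cc3c(Nc4ccc(Cl)c(Cl)c4)ncnc3s2)cc1` gives 3320 nM and compound 2 `N#Cc1cccc(Nc2ncnc3cc(NC(=O)/C=C/c4ccccc4)sc23)c1` gives 17200 nM as the higher of the two numbers, a gap beyond the scatter. Compound 3 `O=C(/C=C/c1ccccc1)Nc1cc2ncnc(Nc3cc(Cl)cc(Cl)c3)c2s1` departs from compound 2 by one change, 3,5-dichlorophenyl in place of 3-cyanophenyl on a nitrogen on an aromatic ring in all: 3,5-dichlorophenyl in place of 3-cyanophenyl on a nitrogen on an aromatic ring. Within the data shown here, no measured step isolates this change. Among the measured compounds shown here, compound 1, the only measured compound with chlorine on its phenyl group, stands at 3320 nM but also differs elsewhere, so only a moderate drop is expected. The estimated change is a 2.5-fold lower number from compound 2 to compound 3 (0.39 log units; beyond the scatter) on this single comparison. Compound 3 is estimated at 7000 nM (range 2200 nM to 20000 nM).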

Compound 3, half-maximal inhibitory concentration: 12500 nM
Estimate against measurement, compound 3: 1.8-fold (0.25 log units) below, and the stated range covers the measured number.
By their numbers in this assay, from the lowest: compound 1; then compounds 3 and 2 (each within the scatter of the next).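

In this assay, the swap of 3-cyanophenyl for 3,5-dichlorophenyl on a nitrogen on an aromatic ring gives a 1.4-fold lower number from compound 2 to compound 3 (0.14 log units; within the scatter). This first direct comparison at this position therefore does not separate the two groups, and the chlorines on this phenyl group bring no change beyond the scatter. Nothing available speaks to why the two groups read alike. Compound 1 differs from compound 3 in more than one place, and its separate reading cannot be tied to any single change. Going by these compounds, whether an amine or a carboxylic acid on this phenyl group would shift the number remains open.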